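A Carbonyl Ring Swap Tested for Cytotoxicity

This account rests on a few compounds, and the source may have more. Where it says the series, first, only, none or still open, it means among the compounds named here.

Compound 2, `COc1cc(-c2nnc3n2NC(c2ccco2)C(C(=O)c2cccs2)S3)cc(OC)c1OC`, was examined in a functional assay on A549 cells (Homo sapiens) for cytotoxicity, read by MTT assay, with a stated time of 48 h (on this read-out higher numbers stand for weaker inhibition and lower numbers for stronger inhibition), where compound 2 gives 78700 nM. Going by the values given here, that is the higher of the two numbers known so far. The other measured compound, compound 1, `COc1cc(-c2nnc3n2NC(c2cccs2)C(C(=O)c2ccc(C)cc2)S3)cc(OC)c1OC`, gives 12700 nM in this assay. Among the compounds with values here, compound 1 and compound 2 differ in two places, so only their two values can be compared, and no single step connects them.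

Compound 3, `COc1cc(-c2nnc3n2NC(c2ccco2)C(C(=O)c2ccc(O)cc2)S3)cc(OC)c1OC`, is not yet measured. It differs from compound 2 in one place: 4-hydroxyphenyl in place of thiophen-2-yl on a carbonyl carbon. A move toward a lower number, beyond the scatter, is expected, because compound 1 with a six-membered aromatic ring of carbon only on its carbonyl carbon gives 12700 nM, though its other ring also differs. The expected step is a 2.6-fold lower number from compound 2 to compound 3 (0.42 log units; beyond the scatter). Compound 3 is estimated at 30000 nM, with a range from 8000 nM to 100000 nM.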

Compound 3, half-maximal inhibitory concentration: 93400 nM
Compound 3: middle estimate off by 3.1-fold (0.49 log units), on the low side; the range from low to high includes it.
By their numbers in this assay, from the lowest: compound 1; then compounds 2 and 3 (each within the scatter of the next).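

Placing 4-hydroxyphenyl in place of thiophen-2-yl on a carbonyl carbon gives, in this assay, a 1.2-fold higher number from compound 2 to compound 3 (0.07 log units; within the scatter), so the two groups cannot be told apart at this position. This is the first comparison shown that changes one place only, and it shows that a six-membered aromatic ring of carbon only, in the form of 4-hydroxyphenyl, does not by itself move the number beyond the scatter here. Nothing available explains why these two groups read alike.

The compounds shown leave open whether an amine or a carboxylic acid in place of the hydroxy group of 4-hydroxyphenyl, or a longer alkyl chain on the carbonyl carbon, would shift the number beyond the scatter. They also leave open whether this swap would read the same with the other ring of compound 1 in place.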